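Shortening the amide cap on the shared core

A few compounds are considered here, and "the series" means these few. Any claim that something is new, unique, unknown or untested is made for them only; others in the source may bear on it.

Measured compounds:
compound 1 `Cc1cccc(Cn2c(CN3CCN(C(=O)c4cccnc4)CC3)nc3ccccc32)c1`: 24.5%
compound 2 `O=C(C1CC1)N1CCN(Cc2nc3ccccc3n2Cc2ccccc2C(F)(F)F)CC1`: 56.3%
compound 3 `CC(C)CCn1c(CN2CCN(C(=O)c3ccco3)CC2)nc2ccccc21`: 42.1%

Of the compounds shown here, three sharing one core have been tested in an assay on isolated protein for inhibition of aldehyde dehydrogenase 1A1 (Homo sapiens), read by spectrophotometry, tested at 10 uM; on this read-out higher numbers stand for more inhibition at the one concentration tested (going by the name of the read-out) and lower numbers for less inhibition. In this assay compound 1 gives 24.5%, the lowest of the three numbers. Compound 3 gives a number higher than that of compound 1 by more than the usual scatter, and compound 2 lies higher still, also beyond the scatter. Each of compounds 2 and 3 differs from compound 1 in more than one place, so none of these gaps can be tied to a single change.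

Compound 4 `CC(=O)N1CCN(Cc2nc3ccccc3n2Cc2cccc(C)c2)CC1` has not yet been measured. It differs from compound 1 in one place:

methyl in place of pyridin-3-yl on a carbonyl carbon

The (pyridin-3-yl)carbonyl cap of compound 1 becomes an acetyl cap. Going by the values given here, no measured pair shows what such a change alone does in this assay, so there is no step to lean on. The step from compound 1 to compound 4 is therefore expected to be small, within the scatter, with no clear direction: a number 3.5 percentage points higher from compound 1 to compound 4 (within the scatter) is the estimated change. For compound 4 the expected value is 28%, with a range from 8% to 50%.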

Compound 4, a percentage reported as inhibition, at one concentration (the size of the read-out at that concentration, not a potency): 70.3%
Estimate against measurement, compound 4: 42.3 percentage points below; measured number above the stated range.
By their numbers in this assay, from the lowest: compound 1; then compound 3; then compound 2; then compound 4.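

In this assay, going by these compounds alone, putting methyl in place of pyridin-3-yl on the carbonyl carbon gives a number 45.8 percentage points higher from compound 1 to compound 4 (beyond the scatter), and this is the first step in the set that can be tied to a single change. It shows that the group on this carbonyl carbon matters a great deal for this read-out, and that in this pair the ring is not needed for inhibition at the one concentration tested, since the much smaller acetyl cap gives the higher number. Nothing measured here gives a reason for the size of this step.

Compounds 2 and 3 differ from compound 4 in more than one place, so the steps to them cannot be read, and their cyclopropyl and furan-bearing caps say nothing clean about how the number depends on the group at this position. An ethyl group or a plain phenyl ring on the same carbonyl carbon, with the rest of compound 1 kept, would separate the loss of the ring nitrogen from the loss of the whole ring and show whether a chain longer than methyl keeps the gain.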